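Furan for Phenyl on an Inactive Nucleoside Analogue

This account rests on a few compounds, and the source may have more. Where it says the series, first, only, none or still open, it means among the compounds named here.

In a functional assay on HCT-116 cells (Homo sapiens), read by MTT assay, with a stated time of 72 h (on this read-out higher numbers stand for weaker inhibition and lower numbers for stronger inhibition), compound 2 `Cc1nc(N)c2c(-c3ccccc3)cn([C@@H]3O[C@H](CO)[C@@H](O)[C@H]3O)c2n1` gives only > 100000 nM, which is a limit of the assay and not a number. Compound 1 `Nc1nc(N)c2c(-c3ccccc3)cn([C@@H]3O[C@H](CO)[C@@H](O)[C@H]3O)c2n1` likewise gives only the limit > 20000 nM in this assay. The step that the two limits leave unreadable from compound 1 to compound 2 therefore cannot be read. Compound 3 `Cc1nc(N)c2c(-c3ccco3)cn([C@@H]3O[C@H](CO)[C@@H](O)[C@H]3O)c2n1` differs from compound 2 by furan-2-yl in place of phenyl on an aromatic carbon. For the measured compounds named here, no measured step shares this exchange, so no shift beyond the scatter is expected from it. The step of a number no higher from compound 2 to compound 3 (the limit leaves the size open) is estimated as flat. Compound 3 is expected to give about 100000 nM, between 30000 nM and 300000 nM, most probably reported once more only as a limit.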

Compound 3, half-maximal inhibitory concentration: > 20000 nM
Compound 3: a limit, no number; the forecaster's own chance of this, stated with the estimate: 80%; the middle value is on the limit's open side.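

In this assay compound 3 gives > 20000 nM, a limit and not a number. Compound 2 also gives only a limit, and the step between compound 2 and compound 3 cannot be read. The compounds shown leave open whether furan-2-yl in place of phenyl changes inhibition at all.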